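Fluoro for Methoxy on a Series Sitting at the Limit

The source may report more compounds than this note shows. Statements on the series, on what has been measured and on what is new or still open speak of the compounds shown alone.

Compound 1 `C=C1C[C@]23C[C@@]1(O)CC[C@H]2c1ccc(OS(=O)(=O)c2ccc(C)cc2)c(C)c1[C@@H]3Cn1cc(-c2ccc(OC)cc2)nn1` in a functional assay on MCF7 cells (Homo sapiens) for cytotoxicity, read by MTT assay, with a stated time of 4 days (on this read-out higher numbers stand for weaker inhibition and lower numbers for stronger inhibition), gives > 20000 nM, which is a limit of the assay.
Compound 2 `C=C1C[C@]23C[C@@]1(O)CC[C@H]2c1ccc(O)c(C)c1[C@@H]3Cn1cc(-c2ccc(OC)cc2)nn1` in this assay gives > 20000 nM, a limit of the assay.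
Compound 3 `C=C1C[C@]23C[C@@]1(O)CC[C@@H]2c1cccc(C)c1[C@@H]3Cn1cc(-c2ccccc2)nn1` in this assay gives > 20000 nM, also a limit of the assay.

Compound 1 therefore stands where every value shown stands, at the limit of > 20000 nM in this assay, at which 3 of the 3 values shown sit; no number separates it from compound 2 or compound 3. Among the compounds with values here, the one single-point step, a step that the two limits leave unreadable from compound 1 to compound 2, has a limit at both ends and so cannot be read in size or direction. Compound 4 `C=C1C[C@]23C[C@@]1(O)CC[C@H]2c1ccc(OS(=O)(=O)c2ccc(C)cc2)c(C)c1[C@@H]3Cn1cc(-c2ccc(F)cc2)nn1` is related to compound 1 by fluoro in place of methoxy on an aromatic carbon. Within the data shown here, no measured step bears on this change, and the only step in this assay gives neither a size nor a direction to build on. The expectation for compound 4 is therefore no readable step in this assay, most likely another limit. The step that the limit leaves unreadable from compound 1 to compound 4 is expected to stay within the scatter. Compound 4 is estimated at 30000 nM, with a range from 15000 nM to 100000 nM.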

Compound 4, half-maximal inhibitory concentration: > 20000 nM
Compound 4 ended at the assay's limit; the forecaster's own chance of this, stated with the estimate: 85%; the middle value does not contradict the limit.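

No new step can be read from compound 1 to compound 4, in size or in direction, as both values are limits: the limit of > 20000 nM in this assay, at which 4 of the 4 values shown sit.

The compounds shown leave open whether fluoro and methoxy differ at all in this assay, and which change to the shared core, if any, would give a measurable value there.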